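The compounds below may be only part of what the source reports. "The series", "measured", "known", "first", "only" and "open" are said of these compounds alone.

Measured compounds:
compound 1, `CC[C@H](C)[C@H](NC(=O)N1CCC2(CC1)C(=O)N(c1cccc(F)c1)C2c1ccc(Cl)cc1)C(=O)OC`, with 45 nM; 872 nM (2 entries) in an assay on HEK293 cells for inhibition of Voltage-dependent T-type calcium channel subunit alpha-1H (Homo sapiens), read by patch clamp, using a membrane potential dye; on this read-out higher numbers stand for weaker inhibition and lower numbers for stronger inhibition
compound 2, `COC(=O)[C@H](CO)NC(=O)N1CCC2(CC1)C(=O)N(c1cccc(F)c1)C2c1ccc(Cl)cc1`, with 3330 nM in this assay

Compound 2 stands as the weakest of the two numbers shown; its value lies well beyond the scatter from either entry of compound 1, while the two entries of compound 1 themselves spread widely, as the several entries of compound 1 in this assay, 45 nM; 872 nM (2 entries) shows. A second entry for compound 2 carries no single number.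

Compound 3, `C[C@H](NC(=O)N1CCC2(CC1)C(=O)N(c1cccc(F)c1)C2c1ccc(Cl)cc1)c1ccccc1`, has not yet been measured. It differs from compound 2 in one place: 1-phenylethyl in place of 2-hydroxy-1-(methoxycarbonyl)ethyl on an amide-type nitrogen. The change removes the ester and the hydroxyl group on the urea nitrogen and brings in an aromatic ring there. Going by the values given here, no measured pair covers this exchange, so the direction can only be guessed from the range of the series. The expected step toward stronger inhibition is estimated at about a 5.6-fold lower number from compound 2 to compound 3 (0.74 log units; beyond the scatter). Compound 3 is estimated at 600 nM, within 100 nM to 4000 nM.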

Compound 3, half-maximal inhibitory concentration: 139 nM
Compound 3: the middle estimate sits 4.3-fold (0.64 log units) above what was measured; the measured number falls inside the stated range.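

Going by these compounds alone, on the amide-type nitrogen, 1-phenylethyl in place of 2-hydroxy-1-(methoxycarbonyl)ethyl gives, in this assay, a 24-fold lower number from compound 2 to compound 3 (1.38 log units; beyond the scatter), the first step that can be read at this position. It shows that inhibition here does not depend on the ester or the hydroxyl group, and that a six-membered aromatic ring of carbon only can stand in their place with a clear gain. Compound 3, at 139 nM, falls between the two widely spread entries of compound 1, so no order can be given for that pair: the several entries of compound 1 in this assay, 45 nM; 872 nM (2 entries)

This one exchange changes several features at once, so the compounds shown do not separate the contributions of the ester, the hydroxyl group and the aromatic ring. They also leave open how a carboxylic acid, an amine or a benzyl group on this nitrogen would read in this assay.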